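Notes on the 3-chlorobenzyl to 4-fluorobenzyl swap

A few compounds are considered here, and "the series" means these few. Any claim that something is new, unique, unknown or untested is made for them only; others in the source may bear on it.

Compound 1 `Nc1ccc(/C=C2\SC(=O)N(Cc3cccc(Cl)c3)C2=O)cc1` and compound 3 `Nc1ccc(/C=C2\SC(=O)N(Cc3ccc(F)cc3)C2=O)cc1` share a core and differ in one place: 4-fluorophenyl in place of 3-chlorophenyl on a saturated chain carbon bound to an amide-type nitrogen in a ring. In a functional assay on CCRF-CEM cells (Homo sapiens) for cytotoxicity, read by cell counting, with a stated time of 3 days (a lower number here means a stronger inhibitor, a higher number a weaker inhibitor), compound 1 gives 18000 nM and compound 3 gives 111000 nM, a step of a 6.2-fold higher number from compound 1 to compound 3 (0.79 log units; beyond the scatter). Compound 2 `C=C(Br)C(=O)Nc1cccc(/C=C2\SC(=O)N(Cc3cccc(Cl)c3)C2=O)c1` keeps the 3-chlorobenzyl group on a different core; in this assay compound 2 gives 1400 nM, the lowest of the three numbers. The difference between the core of compound 2 and the core of compound 1 is not broken down here. Compound 4 `C=C(Br)C(=O)Nc1cccc(/C=C2\SC(=O)N(Cc3ccc(F)cc3)C2=O)c1` stands to compound 2 as compound 3 stands to compound 1: 4-fluorophenyl in place of 3-chlorophenyl on a saturated chain carbon bound to an amide-type nitrogen in a ring, the same change at the same place. Among the measured compounds shown here, the step from compound 2 to compound 4 in this assay is expected to be about a 6.2-fold higher number from compound 2 to compound 4 (0.79 log units; beyond the scatter) because the one earlier instance gave a 6.2-fold higher number from compound 1 to compound 3 (0.79 log units; beyond the scatter), a thin basis of a single pair. Compound 4 is estimated at 8700 nM, with a likely range of 2500 nM to 25000 nM.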

Compound 4, half-maximal inhibitory concentration: 680 nM
Compound 4: the middle estimate sits 13-fold (1.11 log units) above what was measured, and the stated range ends above it.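

In this assay the 3-chlorobenzyl to 4-fluorobenzyl swap does not carry over from the core of compound 1 to the core of compound 2, where the step is a 2.1-fold lower number from compound 2 to compound 4 (0.31 log units; beyond the scatter) and runs the other way. The two steps differ in direction and in size: the same change on two cores in this assay, a 6.2-fold higher number (0.79 log units; beyond the scatter) from compound 1 to compound 3 and a 2.1-fold lower number (0.31 log units; beyond the scatter) from compound 2 to compound 4, 13-fold (1.10 log units) apart, beyond the scatter of two such steps. Among the compounds shown here, one pair on one core is therefore no guide to the step on the other, but two pairs do not show which part of the cores sets the difference, nor how the swap behaves on any further core.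

The swap changes the halogen and its position at once, and the compounds shown do not separate the two. Also open, from the compounds shown here alone, is how an unsubstituted benzyl group or a longer chain in the same place would read on each core.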